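Para groups on a cyanoaziridine aryl urea in L1210 cells

The compounds below may be only part of what the source reports. "The series", "measured", "known", "first", "only" and "open" are said of these compounds alone.

In a functional assay on L1210 cells (Mus musculus) for inhibition, read by MTT assay (a lower number here means a stronger inhibitor, a higher number a weaker inhibitor), the measured compounds are:
compound 1 `CCOC(=O)c1ccc(NC(=O)N2CC2C#N)cc1`: 9700 nM
compound 2 `N#CC1CN1C(=O)Nc1ccc([N+](=O)[O-])cc1`: 2600 nM
compound 3 `N#CC1CN1C(=O)Nc1ccccc1`: 1200 nM

Compound 3, which carries only hydrogen on the aromatic carbon in question, gives the lowest number of the three: a 2.2-fold lower number from compound 2 to compound 3 (0.34 log units; beyond the scatter) and an 8.1-fold lower number from compound 1 to compound 3 (0.91 log units; beyond the scatter), both beyond the scatter, while a 3.7-fold lower number from compound 1 to compound 2 (0.57 log units; beyond the scatter) separates the two substituted compounds.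

Compound 4 `N#CC1CN1C(=O)Nc1ccc(C(F)(F)F)cc1` differs from compound 3 in one place: trifluoromethyl in place of hydrogen on an aromatic carbon. Both measured steps that start from compound 3 in reverse, hydrogen giving way to nitro or to ethoxycarbonyl on an aromatic carbon, raised the number in this assay by a modest amount. The trifluoromethyl group of compound 4 is another replacement of hydrogen at that carbon, so the expected outcome is a modest rise, a 2.1-fold higher number from compound 3 to compound 4 (0.32 log units; beyond the scatter). Compound 4 is therefore estimated at 2500 nM, with a range from 900 nM to 7000 nM.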

Compound 4, half-maximal inhibitory concentration: 7800 nM
The estimate for compound 4 lay 3.1-fold (0.49 log units) below the measured number; measured number outside the range, above it.
By their numbers in this assay, from the lowest: compound 3; then compound 2; then compounds 4 and 1 (each within the scatter of the next).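

In this assay, trifluoromethyl, which brings no hydrogen-bond donors and no hydrogen-bond acceptors, also gives a higher number than hydrogen at this aromatic carbon (a 6.5-fold higher number from compound 3 to compound 4 (0.81 log units; beyond the scatter)), so all three replacements of hydrogen shown go the same way, and none goes against this. The replacing groups are not all alike: trifluoromethyl stands clearly apart from nitro (a 3.0-fold higher number from compound 2 to compound 4 (0.48 log units; beyond the scatter)), yet cannot be told apart from ethoxycarbonyl, the step between them staying within the scatter (a 1.2-fold lower number from compound 1 to compound 4 (0.09 log units; within the scatter)). Nothing available here explains these differences.

As far as these compounds go, how an amine or a methoxy group at this carbon would compare with hydrogen stays open, so the standing of hydrogen holds only against these three groups. From the compounds shown here alone, whether the same replacements would behave alike elsewhere on the aromatic ring also remains open.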